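The source may hold more compounds than are shown below. What is called first, only, known or untested is meant among the compounds shown, and "the series" means these compounds.

Among the compounds with values here, in a functional assay on K562 cells (Homo sapiens) for antiproliferative activity, read by MTT assay, with a stated time of 48 h (a lower number here means a stronger inhibitor, a higher number a weaker inhibitor), compound 1 (`Oc1ccc2cc1Oc1ccc(cc1)CCc1ccc(CN3CCCCC3)c(O)c1-c1ccc(cc1O)CC2`) gives 5880 nM and compound 2 (`CN1CCN(Cc2ccc3c(c2O)-c2ccc(cc2O)CCc2ccc(O)c(c2)Oc2ccc(cc2)CC3)CC1`) gives 3310 nM, so compound 1 stands level with the only other measured compound. Compound 3 (`Oc1cc2ccc1-c1c(ccc(CN3CCCCC3)c1O)CCc1ccc(cc1)Oc1cc(cc(CN3CCCCC3)c1O)CC2`) differs from compound 1 by (piperidin-1-yl)methyl in place of hydrogen on an aromatic carbon, with (piperidin-1-yl)methyl in place of hydrogen on an aromatic carbon, ortho to a hydroxy group. Within the data shown here, the one measured step, a 1.8-fold lower number from compound 1 to compound 2 (0.25 log units; within the scatter), exchanges one amine for another and adds no second group, so it offers only weak guidance. No shift beyond the scatter is therefore expected, and the estimated step is a 1.5-fold lower number from compound 1 to compound 3 (0.17 log units; within the scatter). Compound 3 is expected at 4000 nM, with an estimated range of 1500 nM to 11000 nM.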

Compound 3, half-maximal inhibitory concentration: 660 nM
Compound 3: middle estimate off by 6.1-fold (0.78 log units), on the high side; the measured number lies below the stated range.
By their numbers in this assay, from the lowest: compound 3; then compounds 2 and 1 (each within the scatter of the next).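

In this assay, (piperidin-1-yl)methyl in place of hydrogen on an aromatic carbon, ortho to a hydroxy group, brings an 8.9-fold lower number from compound 1 to compound 3 (0.95 log units; beyond the scatter), whereas exchanging the amine alone brought only a 1.8-fold lower number from compound 1 to compound 2 (0.25 log units; within the scatter). Compound 3 thus shows that this position, which carries hydrogen in compound 1, responds to substitution, and that adding this group changes the number more than that exchange did. Nothing on hand accounts for the gain. On these data alone, whether a smaller amine such as dimethylaminomethyl, or a hydroxymethyl group without nitrogen, would give a similar step at this position remains open.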